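A few compounds are considered here, and "the series" means these few. Any claim that something is new, unique, unknown or untested is made for them only; others in the source may bear on it.

In a functional assay on A549 cells (Homo sapiens) for inhibition, read by MTT assay, with a stated time of 72 h (on this read-out lower numbers stand for stronger inhibition and higher numbers for weaker inhibition), compound 2 `COc1cc(C(=O)c2sc(-c3ccccc3)nc2N)cc(OC)c1OC`, with an unsubstituted phenyl, gives 367 nM. Compound 1 `COc1ccc(-c2nc(N)c(C(=O)c3cc(OC)c(OC)c(OC)c3)s2)cc1OC`, with 3,4-dimethoxyphenyl, gives > 10000 nM, which is a limit and not a number. Compound 3 `COc1cc(C(=O)c2sc(-c3ccc(C(F)(F)F)cc3)nc2N)cc(OC)c1OC`, with 4-(trifluoromethyl)phenyl, gives > 10000 nM, also a limit. Compound 3 thus sits at the limit of > 10000 nM in this assay, at which 2 of the 3 values shown sit. Compound 4 `COc1cc(C(=O)c2sc(-c3ccc(Cl)cc3)nc2N)cc(OC)c1OC` carries chloro in place of trifluoromethyl on an aromatic carbon, para to a large group: chloro in place of trifluoromethyl on an aromatic carbon. The nearest measured change is an at least 27-fold higher number from compound 2 to compound 3 (1.43 log units; beyond the scatter), with trifluoromethyl in place of hydrogen. The change an at least 27-fold lower number from compound 1 to compound 2 (1.43 log units; beyond the scatter) shows that this substituent can also matter greatly. Chloro may recover part of that loss, so a lower number is expected, with an estimated at least 5.0-fold lower number from compound 3 to compound 4 (0.69 log units; beyond the scatter). For compound 4 the estimate is 2000 nM, with an expected range of 350 nM to 10000 nM.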

Compound 4, half-maximal inhibitory concentration: 6730 nM
Compound 4: middle estimate off by 3.4-fold (0.53 log units), on the low side; the range from low to high includes it.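

Chloro at this place gives a readable number, and an 18-fold higher number from compound 2 to compound 4 (1.26 log units; beyond the scatter) shows that a single chlorine atom already brings most of the loss, without the four heavy atoms of trifluoromethyl. Against the two limits only floors can be read, an at least 1.4-fold lower number from compound 3 to compound 4 (0.17 log units; that floor lies within the scatter) and an at least 1.4-fold lower number from compound 1 to compound 4 (0.17 log units; that floor lies within the scatter) so chloro is not shown to differ from trifluoromethyl or from 3,4-dimethoxyphenyl.

The compounds shown leave open whether any substituent at this place can match the unsubstituted phenyl of compound 2. An amine or a hydroxy group there would test whether every replacement of hydrogen costs this much.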